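This account rests on a few compounds, and the source may have more. Where it says the series, first, only, none or still open, it means among the compounds named here.

Measured so far:
compound 1, `O=C(N/N=C/c1cccc(F)c1)c1cccnc1Nc1cccc(C(F)(F)F)c1`: 29.8%
compound 2, `O=C(N/N=C/c1cccc(O)c1)c1cccnc1Nc1cccc(C(F)(F)F)c1`: 35.8%

Among the measured compounds shown here, in a functional assay on the whole organism (strain Wistar) for inhibition, with Rattus norvegicus as the target, read by paw edema, with a stated time of 4 h, at a dose of 10 mg/kg by the intraperitoneal route (on this read-out lower numbers stand for less inhibition and higher numbers for more inhibition at the one dose given (going by the name of the read-out)), compound 2 and compound 1 lie within the scatter of each other, the only measured step being a number 6 percentage points higher from compound 1 to compound 2 (within the scatter). Compound 2 is thus the reference for the next compound, compound 3, `O=C(N/N=C/c1ccc(O)cc1)c1cccnc1Nc1cccc(C(F)(F)F)c1`, which carries the same atoms joined differently: 4-hydroxyphenyl in place of 3-hydroxyphenyl on a carbon with a double bond to nitrogen. For the measured compounds named here, no measured step moves a hydroxy group from one position of this ring to another; the one step recorded, from compound 1 to compound 2, only exchanges the group on that ring and stays within the scatter. There is therefore no basis for expecting a step in this assay beyond the scatter, in either direction, from compound 2 to compound 3. Compound 3 is estimated at 35%, between 22% and 48%, an expected step of a number 0.8 percentage points lower from compound 2 to compound 3 (within the scatter).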

Compound 3, a percentage reported as inhibition, in the whole organism at one dose (the size of the read-out at that dose, not a potency): 61.6%
Compound 3: the middle estimate sits 26.6 percentage points below what was measured, and the stated range ends below it.
By their numbers in this assay, from the lowest: compounds 1 and 2 (each within the scatter of the next); then compound 3.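

In this assay, the exchange of 3-hydroxyphenyl for 4-hydroxyphenyl on a carbon with a double bond to nitrogen gives a number 25.8 percentage points higher from compound 2 to compound 3 (beyond the scatter) with no atom added or lost, so a rearrangement of the same atoms moves this read-out beyond the scatter. The exchange of 3-fluorophenyl for 4-hydroxyphenyl at that same place gives a number 31.8 percentage points higher from compound 1 to compound 3 (beyond the scatter) in this read-out, whereas the step between compound 1 and compound 2 stayed within the scatter. Nothing measured here accounts for the difference between the two hydroxyphenyl groups.

The compounds shown leave open whether 4-fluorophenyl would match 4-hydroxyphenyl, and whether a methoxy group or an amine in place of that hydroxy group would keep the higher number. Also open, on these data alone, is whether the step would hold on a core without the trifluoromethyl group.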